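The source may hold more compounds than are shown below. What is called first, only, known or untested is meant among the compounds shown, and "the series" means these compounds.

In a functional assay on MCF7 cells (Homo sapiens) for cytotoxicity, read by MTT assay, with a stated time of 72 h (on this read-out lower numbers stand for stronger inhibition and higher numbers for weaker inhibition), compound 1 (`O=C1c2c[n+]([O-])c3ccccc3c2C(=O)c2c1c1ccccc1n2CCCCN1CCNCC1`) gives 12000 nM while compound 2 (`O=C1c2c[n+]([O-])c3ccccc3c2C(=O)c2c1c1ccccc1n2CCCCN1CCCCC1`) gives 150 nM and compound 3 (`CN1CCN(CCCn2c3c(c4ccccc42)C(=O)c2c[n+]([O-])c4ccccc4c2C3=O)CC1`) gives 220 nM on the same read-out. Compound 3 thus stands close to one measured neighbour and far from the other, the gaps being a 1.5-fold higher number from compound 2 to compound 3 (0.17 log units; within the scatter) and a 55-fold lower number from compound 1 to compound 3 (1.74 log units; beyond the scatter) on these numbers. Compound 4 (`O=C1c2c[n+]([O-])c3ccccc3c2C(=O)c2c1c1ccccc1n2CCCN1CCC(O)CC1`) has 4-hydroxypiperidin-1-yl in place of 4-methylpiperazin-1-yl on a saturated chain carbon, three bonds along the chain from an aromatic nitrogen. Within the data shown here, the large steps, an 80-fold lower number from compound 1 to compound 2 (1.90 log units; beyond the scatter) and the one already given for compound 3, both start from the piperazin-1-yl of compound 1, a group that compound 4 does not carry, so they bear on this change only weakly. The closer guide is a 1.5-fold higher number from compound 2 to compound 3 (0.17 log units; within the scatter) within the scatter, which sets a piperidin-1-yl end against a 4-methylpiperazin-1-yl end. Among the measured compounds shown here, no measured compound carries a hydroxy group, so that part of the change remains untested. On this evidence no step beyond the scatter is expected in this assay for this change. The estimated step is a 1.1-fold higher number from compound 3 to compound 4 (0.06 log units; within the scatter) on that expectation. For compound 4 the expected value is 250 nM with an estimated range from 80 nM to 900 nM as the likely span.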

Compound 4, half-maximal inhibitory concentration: 190 nM
The estimate for compound 4 lay 1.3-fold (0.12 log units) above the measured number, within the range that was stated.
By their numbers in this assay, from the lowest: compounds 2, 4 and 3 (each within the scatter of the next); then compound 1.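

In this assay, among these compounds, putting 4-hydroxypiperidin-1-yl in place of 4-methylpiperazin-1-yl on the propyl chain gives a 1.2-fold lower number from compound 3 to compound 4 (0.06 log units; within the scatter), which shows for the first time that an end carrying a hydroxy group and a hydrogen-bond donor can stand at this place with no step beyond the scatter. The comparison with the piperidin-1-yl end on the butyl chain, a 1.3-fold higher number from compound 2 to compound 4 (0.10 log units; within the scatter), also stays within the scatter, whereas a 63-fold lower number from compound 1 to compound 4 (1.80 log units; beyond the scatter) is large, so the piperazin-1-yl end stands alone among the four ends shown. Nothing available here offers an explanation for why these ends sit so close together or why the piperazin-1-yl end stands apart.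

Open, as far as these compounds go, is what the hydroxy group itself contributes, as set against a plain piperidin-1-yl end on the same propyl chain, and how a 4-methoxypiperidin-1-yl, morpholin-4-yl or 4-carboxypiperidin-1-yl end would read at this place. Also open, from the compounds shown here alone, is whether the 4-hydroxypiperidin-1-yl end would hold its number on a butyl or longer chain, and whether the piperazin-1-yl end would remain as far apart on the propyl chain.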